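The compounds below may be only part of what the source reports. "The series", "measured", "known", "first", "only" and "open" are said of these compounds alone.

Compound 1 `O=C(NCCCN1CCN(c2ccccn2)CC1)c1cc(Cl)cc(Cl)c1` carries a pyridin-2-yl group on the ring amine nitrogen. In an assay on HEK293 cells for inhibition of sodium-dependent dopamine transporter (Homo sapiens), read by scintillation counting (on this read-out lower numbers stand for stronger inhibition and higher numbers for weaker inhibition), compound 1 gives only a limit, > 10000 nM. Compound 2 `O=C(NCCCN1CCN(c2ncccn2)CC1)c1cc(Cl)cc(Cl)c1` carries pyrimidin-2-yl at that nitrogen instead. In this assay compound 2 likewise gives only a limit, > 10000 nM. The step that the two limits leave unreadable from compound 1 to compound 2 stays unreadable since (the limit of > 10000 nM in this assay, at which 2 of the 2 values shown sit). Compound 3 `O=C(NCCCN1CCN(c2cccc(Cl)c2Cl)CC1)c1cc(Cl)cc(Cl)c1` differs from compound 2 by 2,3-dichlorophenyl in place of pyrimidin-2-yl on an amine nitrogen in a ring. Going by the values given here, no measured step bears readably on this change, and compound 2 stands only at a limit, so direction and size are open. Compound 3 is expected at 2500 nM, with a range from 300 nM to 15000 nM. The step of an at least 4.0-fold lower number from compound 2 to compound 3 (0.60 log units; beyond the scatter) is thus an estimate only.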

Compound 3, half-maximal inhibitory concentration: > 10000 nM
Compound 3: a limit, no number; the forecaster's own chance of this, stated with the estimate: 40%; at least 4.0-fold (0.60 log units) between middle value and limit.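

In this assay compound 3 also gives only a limit, so no step among compound 1, compound 2 and compound 3 can be read: the limit of > 10000 nM in this assay, at which 3 of the 3 values shown sit.

On these data alone, whether pyridin-2-yl, pyrimidin-2-yl and 2,3-dichlorophenyl differ at all in this assay remains open.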